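From 3,5-dimethoxyphenyl to 2,4-dichlorophenyl: expecting compound 3

This account rests on a few compounds, and the source may have more. Where it says the series, first, only, none or still open, it means among the compounds named here.

- compound 1 `COc1cc(/C=C2\CN(C)C/C(=C\c3ccc(Cl)cc3Cl)C2=O)cc(OC)c1`: 6070 nM
- compound 2 `COc1cc(/C=C2\CN(C)C/C(=C\c3cc(OC)c(OC)c(OC)c3)C2=O)cc(OC)c1`: 720 nM

In a functional assay on THP-1 cells (Homo sapiens) for cytotoxicity, read by MTT assay, with a stated time of 24 h (on this read-out lower numbers stand for stronger inhibition and higher numbers for weaker inhibition), compound 2 gives 720 nM, the lower of the two numbers, and the gap up to compound 1 lies beyond the usual scatter. Compound 3 `COc1cc(/C=C2\CN(C)C/C(=C\c3ccc(Cl)cc3Cl)C2=O)cc(OC)c1OC` has 2,4-dichlorophenyl in place of 3,5-dimethoxyphenyl on a double-bonded chain carbon bound to a double-bonded ring carbon. Compound 1 also carries 2,4-dichlorophenyl and gives 6070 nM, so a clear move towards a higher number, meaning weaker inhibition, is expected. The expected change is a 3.5-fold higher number from compound 2 to compound 3 (0.54 log units; beyond the scatter). For compound 3 the estimated value is 2500 nM, with an expected range from 800 nM to 7500 nM.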

Compound 3, half-maximal inhibitory concentration: 5020 nM
Estimate against measurement, compound 3: 2.0-fold (0.30 log units) below, and the stated range covers the measured number.
By their numbers in this assay, from the lowest: compound 2; then compounds 3 and 1 (each within the scatter of the next).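

In this assay, 2,4-dichlorophenyl in place of 3,5-dimethoxyphenyl on a double-bonded chain carbon bound to a double-bonded ring carbon gives a 7.0-fold higher number from compound 2 to compound 3 (0.84 log units; beyond the scatter), so this change at this position clearly matters when only that one place differs. Methoxy in place of hydrogen on an aromatic carbon gives a 1.2-fold lower number from compound 1 to compound 3 (0.08 log units; within the scatter), so that added methoxy makes no readable difference once 2,4-dichlorophenyl is present. Nothing measured here explains either step. From the compounds shown here alone, whether an aromatic ring carrying an amine or a carboxylic acid would give a higher or lower number at this position remains open.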